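Replacing Diethylamino on the Carbonyl of Compound 2

The source may report more compounds than this note shows. Statements on the series, on what has been measured and on what is new or still open speak of the compounds shown alone.

Compound 2 `CCN(CC)C(=O)c1nc(-c2ccc(OC)cc2)c(-c2ccc(OC)cc2)s1` gives < 10 nM in a functional assay with Oryctolagus cuniculus as the target (on this read-out lower numbers stand for stronger inhibition and higher numbers for weaker inhibition), and this is a limit of the assay, not a number. Compound 1 `COc1ccc(-c2nc(/N=C(\N)NC(C)C)sc2-c2ccc(OC)cc2)cc1` gives > 100 nM, which is also a limit. Going by the values given here, compound 2 therefore stands at the strong end of the two values measured so far.

The next structure is compound 3 `COc1ccc(-c2nc(C(=O)N3CCNC(CCO)C3)sc2-c2ccc(OC)cc2)cc1`, and the change is 3-(2-hydroxyethyl)piperazin-1-yl in place of diethylamino on a carbonyl carbon. In short, 3-(2-hydroxyethyl)piperazin-1-yl takes the place of diethylamino on a carbonyl carbon.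

Among the compounds with values here, only one measured step bears on this: an at least 10-fold lower number from compound 1 to compound 2 (1.00 log units; beyond the scatter). That step shows that exchanging the whole group on the aromatic carbon can move the number a long way. However, it involved a different exchange, so it offers only a loose guide to the size of the next step. Within the data shown here, no measured compound yet carries a ring in this group.

A moderate loss of strength is the cautious expectation, and the estimated change is an at least 3.0-fold higher number from compound 2 to compound 3 (0.47 log units; beyond the scatter). Compound 3 is expected at about 30 nM, with an estimated range from 3 nM to 300 nM.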

Compound 3, half-maximal inhibitory concentration: > 1000 nM
Compound 3 gave a limit, no number (the forecaster's own chance of this, stated with the estimate: 40%); middle value at least 33-fold (1.52 log units) from the limit.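

On the carbonyl carbon, the group attached matters greatly: 3-(2-hydroxyethyl)piperazin-1-yl in place of diethylamino gives an at least 100-fold higher number from compound 2 to compound 3 (2.00 log units; beyond the scatter) in this assay, while the rest of the molecule stays the same. The earlier step exchanged a whole group on the aromatic carbon, whereas here the carbonyl stays in place, so the carbonyl alone does not secure a strong result and what sits on it has a large effect. Compound 3 gives > 1000 nM, which is a limit of the assay and not a number, so the step has a floor but no known full size: the limit of > 1000 nM in this assay, at which 1 of the 3 values shown sits.

The exchange brings in a six-membered ring, a second nitrogen and a hydroxyethyl chain all at once, and the compounds shown cannot tell which of these features accounts for the loss. A piperidin-1-yl group on the same carbonyl would test the ring without the second nitrogen or the chain, and an unsubstituted piperazin-1-yl group would test the ring and the second nitrogen without the hydroxyethyl chain.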